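Moving the chlorine on the phenyl ring of a piperazine series

The source may report more compounds than this note shows. Statements on the series, on what has been measured and on what is new or still open speak of the compounds shown alone.

Measured so far:
compound 1 `Nc1scc(CN2CCN(c3c(F)cccc3F)CC2)c1C(=O)c1ccc(Cl)cc1` gives -65%
compound 2 `Nc1scc(CN2CCN(c3cc(F)ccc3F)CC2)c1C(=O)c1ccc(Cl)cc1` gives -59%
compound 3 `Nc1scc(CN2CCN(c3cccc(Cl)c3)CC2)c1C(=O)c1ccc(Cl)cc1` gives -59%

All three numbers come from a functional assay on CHO cells with adenosine receptor A1 (Homo sapiens) as the target, read by cAMP accumulation and immunoassay, with a stated time of 6 min, tested at 1 uM; a higher number here means a weaker effect of the compound at the concentration tested, a lower number a stronger effect. Compound 3 stands level with compound 2 at the digits printed, and the two together are the highest of the three numbers; compound 1 is the furthest away, and even that gap, a number 6 percentage points higher from compound 1 to compound 3 (within the scatter), is within the scatter. Compound 4 `Nc1scc(CN2CCN(c3ccccc3Cl)CC2)c1C(=O)c1ccc(Cl)cc1` differs from compound 3 only on the phenyl ring that sits on the amine nitrogen of the ring: 2-chlorophenyl in place of 3-chlorophenyl on an amine nitrogen in a ring.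

For the measured compounds named here, three steps bear on this change, each of them a swap of one substituted phenyl ring for another at the same place: a number 6 percentage points higher from compound 1 to compound 2 (within the scatter), a number 6 percentage points higher from compound 1 to compound 3 (within the scatter) and no change at the digits printed from compound 2 to compound 3 (within the scatter). Going by the values given here, none of them leaves the scatter, so the place of the halogen on this phenyl ring has not shifted the read-out in this assay so far. The expected step is therefore none beyond the scatter, a number 1 percentage points lower from compound 3 to compound 4 (within the scatter). Compound 4 is estimated to give -60%, with a range from -72% to -48%.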

Compound 4, a percentage reported as activity, at one concentration (the size of the read-out at that concentration, not a potency): -5.2%
Beside the measured number, compound 4's estimate is 54.8 percentage points below it; the whole stated range lies below it.
By their numbers in this assay, from the lowest: compounds 1, 2 and 3 (each within the scatter of the next); then compound 4.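

Moving the chlorine alone matters at this place on the ring nitrogen: the entering 2-chlorophenyl and the leaving 3-chlorophenyl have the same atoms, yet the swap gives a number 53.8 percentage points higher from compound 3 to compound 4 (beyond the scatter) and so a much weaker effect. The two fluorinated compounds show a gap of the same kind, with a number 53.8 percentage points higher from compound 2 to compound 4 (beyond the scatter) and a number 59.8 percentage points higher from compound 1 to compound 4 (beyond the scatter), and they go against any simple rule about a halogen at the 2 place, since their 2,5-difluorophenyl and 2,6-difluorophenyl groups also carry one there and still have the stronger effect. Nothing measured here explains why this single change has so large an effect.

From the compounds shown here alone, it remains open whether a lone fluorine, a methyl or a methoxy group at the 2 place of this phenyl ring would behave like the chlorine of compound 4. Going by these compounds, it is also open whether a 2,6-dichlorophenyl group would follow compound 1 or compound 4.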